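A Halogen Swap on a Weak Antiproliferative Scaffold

This account rests on a few compounds, and the source may have more. Where it says the series, first, only, none or still open, it means among the compounds named here.

Compound 1 `CCCSc1nc(N/N=C/c2ccccc2F)c2nnn(Cc3ccccc3)c2n1` was examined in a functional assay on MCF7 cells (Homo sapiens) for antiproliferative activity, read by MTT assay, with a stated time of 72 h; a lower number here means a stronger inhibitor, a higher number a weaker inhibitor. For compound 1 the outcome is a limit of the assay, > 64000 nM, so no number is known for it. Compound 1 therefore stands at the limit of > 64000 nM in this assay, at which 1 of the 3 values shown sits. Two companions with other substituents return numbers: compound 2 `CCCSc1nc(N/N=C(\C)c2ccccc2O)c2nnn(Cc3ccco3)c2n1` gives 29000 nM in this assay, and compound 3 `C#CCSc1nc(N/N=C/c2cc(OC)c(OC)c(OC)c2)c2nnn(Cc3ccccc3)c2n1` gives 17000 nM in this assay. Neither differs from compound 1 in a single place, so their values show only where this group of compounds sits, in the weak range. Compound 4 `CCCSc1nc(N/N=C/c2ccc(Br)cc2)c2nnn(Cc3ccccc3)c2n1` remains to be measured in this assay. It differs from compound 1 in one place: 4-bromophenyl in place of 2-fluorophenyl on a carbon with a double bond to nitrogen. Within the data shown here, no measured step between two compounds of this set exists, so the size of this change cannot be read from a neighbour. Because compound 1 rests at the limit of > 64000 nM in this assay, at which 1 of the 3 values shown sits, the writer expects compound 4 to stay weak, with a step no larger than the scatter or a small gain at most. Compound 4 is estimated at 45000 nM, with a range from 15000 nM to 130000 nM. That estimate implies the expected step of an at least 1.4-fold lower number from compound 1 to compound 4 (0.15 log units; that floor lies within the scatter).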

Compound 4, half-maximal inhibitory concentration: > 64000 nM
Compound 4: only a limit was reported (the forecaster's own chance of this, stated with the estimate: 55%); middle value at least 1.4-fold (0.15 log units) from the limit.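

In this assay compound 4 gives only a limit, > 64000 nM. Compound 1 also gives only a limit, so no step from compound 1 to compound 4 can be read: the limit of > 64000 nM in this assay, at which 2 of the 4 values shown sit.

The compounds shown leave open whether 4-bromophenyl and 2-fluorophenyl differ on this read-out at all, and in which direction.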